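A few compounds are considered here, and "the series" means these few. Any claim that something is new, unique, unknown or untested is made for them only; others in the source may bear on it.

Of the compounds shown here, three built on one shared core have been measured in a functional assay on THP-1 cells (Homo sapiens) for inhibition, read by sulforhodamine B assay, with a stated time of 48 h, tested at 50 uM; a lower number here means less inhibition of growth, a higher number more inhibition of growth at the concentration tested. Compound 2 `COc1ccc2c(c1)C(=O)C(=O)N2CCCn1cc(COc2cc(=O)oc3ccccc23)nn1` gives 56%, compound 3 `COc1ccc2c(c1)C(=O)C(=O)N2CCCCn1cc(COc2cc(=O)oc3ccccc23)nn1` gives 52%, and compound 1 `COc1ccc2c(c1)C(=O)C(=O)N2CCCCCn1cc(COc2cc(=O)oc3ccccc23)nn1` gives 30%, the lowest of the three numbers. Its gaps to compound 3 and to compound 2 both lie beyond the usual scatter of repeated measurements, so compound 1 is the weakest inhibitor of growth among the three at this concentration.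

Compound 4 `O=C1C(=O)N(CCCCCn2cc(COc3cc(=O)oc4ccccc34)nn2)c2ccc(Cl)cc21` has not yet been tested. It differs from compound 1 in a single place: chloro in place of methoxy on an aromatic carbon. Among the measured compounds shown here, no pair of already measured compounds differs in this way, so the size of the step cannot be read off any earlier comparison. The working expectation is a step from compound 1 that stays within the usual scatter, a number 2 percentage points higher from compound 1 to compound 4 (within the scatter), with no clear direction. Compound 4 is therefore expected to give about 32%, in a range from 15% to 50%.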

Compound 4, percent growth inhibition at one concentration: 59%
Beside the measured number, compound 4's estimate is 27 percentage points below it, outside the stated range (above it).
By their numbers in this assay, from the lowest: compound 1; then compounds 3, 2 and 4 (each within the scatter of the next).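

In this assay, putting chloro in place of methoxy on this aromatic carbon gives a number 29 percentage points higher from compound 1 to compound 4 (beyond the scatter), so the group at this position of the shared core can clearly change growth inhibition at the concentration tested. The earlier compounds shown here all carried methoxy here and differed only in their chains, so they could not show this. No measurement at hand accounts for the step, which rests on this single pair of compounds.

On these data alone, it remains open whether the same change would give a similar step on the shorter chains of compound 2 and compound 3. It is also unclear how fluoro, bromo or an amine at this position would compare with chloro, and so whether the step reflects the arrival of chloro or simply the loss of methoxy.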